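The source may hold more compounds than are shown below. What is called first, only, known or untested is meant among the compounds shown, and "the series" means these compounds.

In a functional assay on KB cells (Homo sapiens) for inhibition, read by MTT assay, with a stated time of 24 h, tested at 1 ug/mL (a lower number here means less inhibition of growth, a higher number more inhibition of growth at the concentration tested), compound 1 (`O=C(CCCCC1CCSS1)NO`) gives 2.57% and compound 2 (`O=C(CCCCC(S)CCS)NO`) gives 10.6% so these two values lie within the scatter of each other. Compound 3 (`O=C(CCCCC(S)CCS)Nc1ccccc1`) differs from compound 2 by carrying phenyl in place of hydroxy on an amide-type nitrogen. Going by the values given here, no measured step shows what this change does. In this assay the expected change is small, slightly upward and not beyond the scatter, with a number 4.4 percentage points higher from compound 2 to compound 3 (within the scatter) as the estimate. For compound 3 the expected value is 15% (estimated range 2% to 40%).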

Compound 3, percent growth inhibition at one concentration: 11.6%
Compound 3: middle estimate off by 3.4 percentage points, on the high side, within the range that was stated.
By their numbers in this assay, from the lowest: compounds 1, 2 and 3 (each within the scatter of the next).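

In this assay, going by these compounds alone, the exchange of phenyl for hydroxy on an amide-type nitrogen gives a number 1 percentage points higher from compound 2 to compound 3 (within the scatter) and so provides the first readable step at this position. Six heavy atoms and an aromatic ring enter where one oxygen leaves, and a hydrogen-bond donor and acceptor are lost, yet the read-out at this one concentration stays within the scatter. The hydroxy is therefore not required to keep the number where it stands.

As far as these compounds go, what a methyl or a benzyl on this nitrogen would give remains open, as does a carboxylic acid in place of the amide. Nothing at hand explains why the exchange leaves the read-out within the scatter.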